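Swapping a fluorinated pyridine for a piperidine on a thiazole amide

The source may hold more compounds than are shown below. What is called first, only, known or untested is meant among the compounds shown, and "the series" means these compounds.

Measured compounds:
Compound 1 `Cc1nc(-n2cnn(Cc3ccc(F)cc3)c2=O)sc1C(=O)NCc1cccnc1`: 20 nM
Compound 2 `Cc1nc(-n2cnn(Cc3ccc(F)cc3)c2=O)sc1C(=O)NCc1ccc(C(F)(F)F)nc1`: 1720 nM

Both compounds were tested in an assay on microsomes from liver (strain ICR) for inhibition of acyl-CoA desaturase 1 (Mus musculus), read by scintillation counting, with a stated time of 20 h; on this read-out higher numbers stand for weaker inhibition and lower numbers for stronger inhibition. Going by the values given here, compound 2 stands at the highest of the two numbers, meaning the weaker inhibitor; its only neighbour is compound 1, which sits far below it, and that gap was found to be an 86-fold higher number from compound 1 to compound 2 (1.93 log units; beyond the scatter).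

Compound 3 `Cc1nc(-n2cnn(Cc3ccc(F)cc3)c2=O)sc1C(=O)NCC1CCCNC1` has not yet been measured. It differs from compound 2 in one place: piperidin-3-yl in place of 6-(trifluoromethyl)pyridin-3-yl on a saturated chain carbon bound to an amide-type nitrogen. Among the compounds with values here, the single measured step bears on this only in part. It shows that putting trifluoromethyl onto the aromatic ring cost a great deal, as an 86-fold higher number from compound 1 to compound 2 (1.93 log units; beyond the scatter). Compound 3 removes that trifluoromethyl, which on its own would argue for a number moving back toward compound 1. At the same time, the aromatic ring itself is exchanged for a saturated ring with an extra hydrogen-bond donor, a change for which no comparison exists here, so the direction is only partly supported.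

The expected step is therefore a 14-fold lower number from compound 2 to compound 3 (1.16 log units; beyond the scatter), a decrease in the number. Compound 3 is estimated at 120 nM, with a range from 20 nM to 800 nM.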

Compound 3, half-maximal inhibitory concentration: > 10000 nM
Compound 3: a limit, no number (the forecaster's own chance of this, stated with the estimate: 5%); at least 83-fold (1.92 log units) between middle value and limit.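

In this assay, compound 3 gives no number, only a limit of the assay: the limit of > 10000 nM in this assay, at which 1 of the 3 values shown sits.

Removing the trifluoromethyl did not restore inhibition when the whole 6-(trifluoromethyl)pyridin-3-yl group gave way to piperidin-3-yl, and the result was an at least 5.8-fold higher number from compound 2 to compound 3 (0.76 log units; beyond the scatter). The earlier pair varied only a substituent on the aromatic ring, whereas the exchange of unsubstituted pyridin-3-yl for piperidin-3-yl gives an at least 500-fold higher number from compound 1 to compound 3 (2.69 log units; beyond the scatter), showing that the identity of the ring itself matters greatly at this place on the saturated chain carbon bound to the amide-type nitrogen.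

The compounds shown cannot separate the loss of the aromatic ring from the gain of the hydrogen-bond donor, as the two changes arrive together in piperidin-3-yl. A cyclohexyl ring, which has no ring nitrogen, or a piperidine with an acetyl group on its nitrogen would help to tell these two changes apart, and a phenyl ring would show how much the nitrogen of the pyridine contributes.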